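The source may hold more compounds than are shown below. What is called first, only, known or untested is meant among the compounds shown, and "the series" means these compounds.

Going by the values given here, compound 2 `COc1cccc(-c2c(C)n(Cc3c(F)cccc3F)c(=O)n(C[C@H](NC(C)C)C3CCCCC3)c2=O)c1F` gives 23 nM in an assay on HEK293 cells for binding affinity to Gonadotropin-releasing hormone receptor (Homo sapiens), read by radioligand binding (on this read-out lower numbers stand for stronger inhibition and higher numbers for weaker inhibition), the lower of the two numbers measured so far; compound 1 `COc1cccc(-c2c(C)n(Cc3c(F)cccc3F)c(=O)n(C[C@H](C)NCc3ccccc3)c2=O)c1F` gives 51 nM. Among the compounds with values here, the one measured step, a 2.2-fold lower number from compound 1 to compound 2 (0.35 log units; beyond the scatter), changed the same place of the molecule. Compound 3 `COc1cccc(-c2c(C)n(Cc3c(F)cccc3F)c(=O)n(C[C@H](N)CC(C)C)c2=O)c1F` differs from compound 2 by 1-amino-3-methylbutyl in place of cyclohexyl(isopropylamino)methyl on a saturated chain carbon bound to an aromatic nitrogen, so the ring and the branched group on the nitrogen both go. This change is larger than the measured one and points in no firm direction, so compound 3 is expected to give a somewhat higher number, a step of a 3.5-fold higher number from compound 2 to compound 3 (0.54 log units; beyond the scatter). Compound 3 is estimated at 80 nM, with a likely range from 25 nM to 250 nM.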

Compound 3, inhibition constant: 6.4 nM
The estimate for compound 3 lay 13-fold (1.10 log units) above the measured number; the whole stated range lies above it.
By their numbers in this assay, from the lowest: compound 3; then compound 2; then compound 1.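

In this assay, the smaller 1-amino-3-methylbutyl group, with no ring and nothing added on its nitrogen, gives a 3.6-fold lower number from compound 2 to compound 3 (0.56 log units; beyond the scatter) and an 8.0-fold lower number from compound 1 to compound 3 (0.90 log units; beyond the scatter). So at this position, neither a cyclohexyl ring nor a substituent on the amine nitrogen is needed for a low number. Nothing available explains this result.

Going by these compounds, the ring and the isopropyl group leave together, so their separate contributions remain open. A cyclohexyl(amino)methyl group, which keeps the ring on a bare amine, would tell them apart.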